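Dropping one methoxy from the aryl of compound 1

The source may report more compounds than this note shows. Statements on the series, on what has been measured and on what is new or still open speak of the compounds shown alone.

In a functional assay on HCT-15 cells (Homo sapiens) for cytotoxicity, read by sulforhodamine B assay, with a stated time of 48 h, tested at 0.1 uM (a higher number here means a weaker effect of the compound at the concentration tested, a lower number a stronger effect), compound 1 `COc1cc(-c2cc(/C=C/C(=O)c3ccc(N)cc3)[nH]n2)cc(OC)c1OC` gives 94%. Compound 3 `COc1cc(-c2cc(/C=C/C(=O)c3ccc(Cl)c(Cl)c3)[nH]n2)cc(OC)c1OC` gives 94%, and compound 2 `COc1ccc(-c2cc(/C=C/C(=O)c3ccc(OC)c(OC)c3)[nH]n2)cc1` gives 97%; all three numbers sit within the scatter of one another, so compound 1 is not separated from either of them. Within the data shown here, the one single-site step in the set, no change at the digits printed from compound 1 to compound 3 (within the scatter), shows that replacing the aryl on the carbonyl leaves the read-out where it was.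

Compound 4 `COc1ccc(-c2cc(/C=C/C(=O)c3ccc(N)cc3)[nH]n2)cc1OC` differs from compound 1 at a different place: hydrogen in place of methoxy on an aromatic carbon. Among the measured compounds shown here, no measured pair changes the methoxy pattern on that ring, so the only guide is the general picture, in which every compound and the single measured step cluster near the top of the scale at this concentration. On that basis no step beyond the scatter is expected, a number 1 percentage points higher from compound 1 to compound 4 (within the scatter). For compound 4 the estimate in this assay is 95%, with a range from 85% to 100%.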

Compound 4, a percentage reported as activity, at one concentration (the size of the read-out at that concentration, not a potency): 95%
Compound 4: the middle estimate sits on the measured number at the digits printed, within the range that was stated.
By their numbers in this assay, from the lowest: compounds 1, 3, 4 and 2 (each within the scatter of the next).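

In this assay, among these compounds, the step of a number 1 percentage points higher from compound 1 to compound 4 (within the scatter) gives the first reading on the methoxy pattern of the ring opposite the carbonyl side, since the earlier single-site step changed only the aryl on the carbonyl. Hydrogen in place of methoxy on this aromatic carbon, ortho to a methoxy group and meta to a large group, therefore leaves the read-out of this pair unseparated at the one concentration tested, so this methoxy is not required to hold that read-out in this pair. No measurement given here bears on the reason for this result.

On these data alone, whether a hydroxyl or an ethoxy at this place would move the read-out stays open. Also open, as far as these compounds go, is whether hydrogen in place of this methoxy would give the same result with 3,4-dichlorophenyl on the carbonyl.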